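Changing the aryl ketone on a weak triazole-type scaffold

The compounds below may be only part of what the source reports. "The series", "measured", "known", "first", "only" and "open" are said of these compounds alone.

Values in a functional assay on PC-3 cells (Homo sapiens) for inhibition, read by MTT assay, with a stated time of 48 h; on this read-out higher numbers stand for weaker inhibition and lower numbers for stronger inhibition:
- Compound 1 `COc1ccc(CSc2nnc(-c3cc(OC)c(OC)c(OC)c3)n2-c2ccc(N(C)C)cc2)cc1`: > 60000 nM
- Compound 2 `COc1ccc(C(=O)CSc2nnc(-c3cc(OC)c(OC)c(OC)c3)n2-c2ccc(N(C)C)cc2)cc1`: 22000 nM

The value of compound 1, > 60000 nM, is a limit of the assay and not a number. Among the measured compounds shown here, compound 2, at 22000 nM, therefore carries the only exact number so far. Compound 3 `COc1cc(-c2nnc(SCC(=O)c3ccc4ccccc4c3)n2-c2ccc(N(C)C)cc2)cc(OC)c1OC` has naphthalen-2-yl in place of 4-methoxyphenyl on a carbonyl carbon. For the measured compounds named here, one measured step bears on this change, and only indirectly: an at least 2.7-fold lower number from compound 1 to compound 2 (0.43 log units; beyond the scatter). That step rests on (the limit of > 60000 nM in this assay, at which 1 of the 2 values shown sits), and it did not swap this aryl group. Going by that step alone, a modest move towards lower numbers in this assay is expected, on thin support. The expected step is a 2.0-fold lower number from compound 2 to compound 3 (0.30 log units; within the scatter). Compound 3 is estimated at 11000 nM, with an expected range of 3000 nM to 40000 nM.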

Compound 3, half-maximal inhibitory concentration: 18100 nM
Beside the measured number, compound 3's estimate is 1.6-fold (0.22 log units) below it; the measured number falls inside the stated range.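

In this assay, naphthalen-2-yl in place of 4-methoxyphenyl on a carbonyl carbon gives a 1.2-fold lower number from compound 2 to compound 3 (0.08 log units; within the scatter) and so leaves the two aryl ketones indistinguishable, even though the entering group has two six-membered aromatic rings of carbon only and no hydrogen-bond acceptor. The (naphthalen-2-yl)carbonyl group in place of 4-methoxyphenyl on a saturated chain carbon bound to a sulfur gives an at least 3.3-fold lower number from compound 1 to compound 3 (0.52 log units; beyond the scatter) and thus shows that the move to lower numbers seen with the first ketone also holds for a second aryl ketone. From the compounds shown here alone, the size of that step stays open, since the value at its start is a limit and not a number: the limit of > 60000 nM in this assay, at which 1 of the 3 values shown sits.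

Going by these compounds, how an amine or a carboxylic acid in place of the aryl group on the carbonyl carbon would read remains open. So does the effect of a longer chain in place of the saturated chain bound to the sulfur.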